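The source may report more compounds than this note shows. Statements on the series, on what has been measured and on what is new or still open speak of the compounds shown alone.

Measured in a functional assay on NCI-H1299 cells (Homo sapiens) for antiproliferative activity, read by MTT assay, with a stated time of 48 h; on this read-out lower numbers stand for stronger inhibition and higher numbers for weaker inhibition:
Compound 1 `Cc1ccc2c(c1)C1(C(=O)N2C)C(C#N)=C(N)Oc2cc3oc(-c4ccccc4)cc(=O)c3c(O)c21` gives 10200 nM.
Compound 2 `Cc1ccc2c(c1)C1(C(=O)N2Cc2ccccc2)C(C#N)=C(N)Oc2cc3oc(-c4ccccc4)cc(=O)c3c(O)c21` gives only a limit of the assay, > 50000 nM.

Within this assay, compound 2 thus stands at the limit of > 50000 nM in this assay, at which 1 of the 2 values shown sits, and no numerical value is known for it. For the measured compounds named here, the single measured step, an at least 4.9-fold higher number from compound 1 to compound 2 (0.69 log units; beyond the scatter), alters another part of the molecule and does not touch the ring changed here. Compound 3 `Cc1ccc2c(c1)C1(C(=O)N2Cc2ccccc2)C(C#N)=C(N)Oc2cc3oc(-c4ccccc4F)cc(=O)c3c(O)c21` differs from compound 2 by fluoro in place of hydrogen on an aromatic carbon. Going by the values given here, none of the measured steps concerns a fluoro in place of hydrogen on this ring, so nothing on hand points in either direction, and no step beyond the scatter is expected in this assay. Compound 3 is therefore expected to remain near the limit, with a step that the limit leaves unreadable from compound 2 to compound 3 as the expected change from compound 2. The estimate for compound 3 is 60000 nM, within 20000 nM to 150000 nM, and most likely only a limit will again be reported.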

Compound 3, half-maximal inhibitory concentration: > 50000 nM
Compound 3: only a limit was reported; the forecaster's own chance of this, stated with the estimate: 70%; the middle value does not contradict the limit.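

For the compounds shown here, compound 2 and compound 3 both sit at a limit of the assay rather than at a number, so no step between them can be read: the limit of > 50000 nM in this assay, at which 2 of the 3 values shown sit. The compounds shown leave open whether going from phenyl to 2-fluorophenyl alters activity when the starting compound has a readable value, as compound 1 does.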